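Swapping Isopropyl for 2-Fluorophenyl on the Urea Nitrogen

This account rests on a few compounds, and the source may have more. Where it says the series, first, only, none or still open, it means among the compounds named here.

Compound 1 `CCOC(=O)c1cnn(CC(O)CC)c1NC(=O)NC(C)C` carries an isopropyl group on one nitrogen of its urea and a 1-hydroxypropyl-bearing chain on the aromatic nitrogen of the shared core. In a functional assay on cells (Neutrophil, Homo sapiens) for inhibition, with a stated time of 10 min (on this read-out lower numbers stand for stronger inhibition and higher numbers for weaker inhibition), compound 1 gives only a limit, > 10 nM, not a number. Two close relatives do give numbers. Compound 2 `CCOC(=O)c1cnn(CC(C)O)c1NC(=O)NC(C)C`, with 1-hydroxyethyl in place of 1-hydroxypropyl on that chain carbon, gives 90 nM in this assay. Compound 3 `CCOC(=O)c1cnn(C)c1NC(=O)NC(C)C`, with hydrogen in place of the whole hydroxy chain on the carbon bound to the aromatic nitrogen, gives 77 nM. The steps a step that the limit leaves unreadable from compound 1 to compound 2 and a step that the limit leaves unreadable from compound 1 to compound 3 cannot be sized because of the limit of > 10 nM in this assay, at which 1 of the 3 values shown sits. The step of a 1.2-fold lower number from compound 2 to compound 3 (0.07 log units; within the scatter) leaves these two within the usual scatter of each other.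

Compound 4 `CCOC(=O)c1cnn(CC(O)CC)c1NC(=O)Nc1ccccc1F` differs from compound 1 at the opposite end of the molecule: 2-fluorophenyl in place of isopropyl on an amide-type nitrogen. Among the measured compounds shown here, none of the measured steps touches this amide-type nitrogen, so none bears directly on the size or direction of this change. The expectation therefore rests on the level of the relatives: compound 2 gives 90 nM and compound 3 gives 77 nM, so compound 4 is estimated at 60 nM, within a range of 12 nM to 300 nM. Relative to compound 1 this amounts to an expected step that the limit leaves unreadable from compound 1 to compound 4.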

Compound 4, half-maximal inhibitory concentration: 120 nM
Beside the measured number, compound 4's estimate is 2.0-fold (0.30 log units) below it, and the stated range covers the measured number.
By their numbers in this assay, from the lowest: compounds 3, 2 and 4 (each within the scatter of the next).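

No new step can be read from this result. Compound 4 has a number, but its only one-place partner, compound 1, is held as a limit, so the change between them cannot be sized, because of this: the limit of > 10 nM in this assay, at which 1 of the 4 values shown sits.

The compounds shown leave open how large the effect of 2-fluorophenyl in place of isopropyl on the amide-type nitrogen is in this assay, and in which direction it runs.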